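The compounds below may be only part of what the source reports. "The series", "measured", "known", "first", "only" and "open" are said of these compounds alone.

Series notes. Three members of the shared core have been run in an ADME assay on microsomes from liver (Mus musculus) for metabolic stability, read by LC-MS, with NADPH named in the record, with a stated time of 60 min, tested at 1 uM, in the absence of a further agent; on this read-out lower numbers stand for a less stable compound and higher numbers for a more stable compound: compound 1 `CC(=O)N[C@@H]1CCN(c2cc(C)nn3c(-c4ccc(C#N)cc4)c(C)nc23)C1`, compound 2 `CC(=O)N[C@@H]1CCN(c2cc(C)nn3c(-c4ccco4)c(C)nc23)C1` and compound 3 `COc1ccc(-c2c(C)nc3c(N4CC[C@@H](NC(=O)c5ccccc5)C4)cc(C)nn23)cc1OC`. In this assay compound 1 gives > 95%, which is a limit of the assay and not a number. Compound 2 gives > 95% in this assay, again a limit. Compound 3 gives > 95% in this assay, also a limit. Among the measured compounds shown here, all three values sit at the limit of > 95% in this assay, at which 3 of the 3 values shown sit, so the one measured step, a step that the two limits leave unreadable from compound 1 to compound 2, cannot be read for size or direction. Compound 3 thus stands at the limit of the read-out, and nothing in the set places it above or below its neighbours.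

Compound 4 `COc1ccc(-c2c(C)nc3c(N4CC[C@@H](NS(C)(=O)=O)C4)cc(C)nn23)cc1OC` is the next member. Its difference from compound 3 is methylsulfonyl in place of benzoyl on an amine nitrogen. For the measured compounds named here, no measured step bears on a change of this kind, and the only step in hand, a step that the two limits leave unreadable from compound 1 to compound 2, lies between two limits. Compound 4 is expected to stay at the limit, a step of a number no higher from compound 3 to compound 4 (the limit leaves the size open) that is none beyond the scatter. The estimate for compound 4 is 95%, between 85% and 99%.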

Compound 4, percent of the compound remaining: > 95%
Compound 4 gave a limit, no number; the forecaster's own chance of this, stated with the estimate: 70%; the middle value sits exactly at the limit.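

Compound 4 gives > 95% in this assay, which is a limit and not a number. The step between compound 3 and compound 4 therefore cannot be read for size or direction: the limit of > 95% in this assay, at which 4 of the 4 values shown sit. The compounds shown leave open how stability differs among these four, and whether any change on the shared core lowers it.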